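This account rests on a few compounds, and the source may have more. Where it says the series, first, only, none or still open, it means among the compounds named here.

Working notes on the urea series.

Three compounds have been run in a functional assay on A549 cells (Homo sapiens) for inhibition, read by sulforhodamine B assay, with a stated time of 48 h, tested at 0.01 uM; on this read-out higher numbers stand for a weaker effect at the one concentration tested and lower numbers for a stronger effect. Compound 1 `COc1cc(Cl)cc(-c2nn(-c3cccc(NC(=O)Nc4ccc(Cl)c(C(F)(F)F)c4)c3)cc2-c2ccncc2)c1` gives 97%. Compound 2 `COc1cc(Cl)cc(-c2nn(-c3cccc(NC(=O)Nc4cc(C(F)(F)F)cc(C(F)(F)F)c4)c3)cc2-c2ccncc2)c1` gives 100%. Compound 3 `COc1cc(Cl)cc(-c2nn(-c3cccc(NC(=O)Nc4ccc(Cl)c(Cl)c4)c3)cc2-c2ccncc2)c1` gives 99%. On these numbers compound 3 stands second of the three: the nearest is compound 2, the furthest compound 1, and both gaps are within the scatter, so no order among the three can be read. Among the compounds with values here, the one single-point step measured so far, a number 2 percentage points higher from compound 1 to compound 3 (within the scatter), is flat.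

Compound 4 `COc1cc(Cl)cc(-c2nn(-c3cccc(NC(=O)Nc4cccc(C(F)(F)F)c4)c3)cc2-c2ccncc2)c1` has not yet been measured. The change from compound 3 is 3-(trifluoromethyl)phenyl in place of 3,4-dichlorophenyl on an amide-type nitrogen. Within the data shown here, the only step that bears on it is a number 2 percentage points higher from compound 1 to compound 3 (within the scatter), which also swaps chloro and trifluoromethyl on the urea-bound aromatic ring without moving the number beyond the scatter. With all three measured values close to the top of the read-out, no step beyond the scatter is expected in this assay in either direction. Compound 4 is therefore estimated at 98%, with a range of 90% to 105%. The expected step is a number 1 percentage points lower from compound 3 to compound 4 (within the scatter).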

Compound 4, a percentage reported as activity, at one concentration (the size of the read-out at that concentration, not a potency): 100%
Estimate against measurement, compound 4: 2 percentage points below; the measured number falls inside the stated range.
By their numbers in this assay, from the lowest: compounds 1, 3, 2 and 4 (each within the scatter of the next).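

In this assay, within the data shown here, the change at the amide-type nitrogen from 3,4-dichlorophenyl to 3-(trifluoromethyl)phenyl gives a number 1 percentage points higher from compound 3 to compound 4 (within the scatter) and is the first step here that replaces the whole aryl group in one comparison. Compound 4 also gives the first read on taking a substituent away from that ring: hydrogen in place of trifluoromethyl gives no change at the digits printed from compound 2 to compound 4 (within the scatter) and hydrogen in place of chloro gives a number 3 percentage points higher from compound 1 to compound 4 (within the scatter). At this one concentration, therefore, neither the second substituent on the ring nor its identity separates the four compounds.

From the compounds shown here alone, whether a ring carrying a methoxy group, an amine or a carboxylic acid, or a longer alkyl chain in place of the aryl group, would shift the number remains open. No evidence is available on why the read-out stays flat across this position.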